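A few compounds are considered here, and "the series" means these few. Any claim that something is new, unique, unknown or untested is made for them only; others in the source may bear on it.

Measured so far in an assay on isolated protein for inhibition of RAC-alpha serine/threonine-protein kinase (Homo sapiens), tested at 30 uM; on this read-out higher numbers stand for more inhibition at the one concentration tested (going by the name of the read-out) and lower numbers for less inhibition:

compound 1 `Clc1ncnc2c1ncn2Cc1ccccc1` gives 0%
compound 2 `Fc1ccc(Cn2cnc3c(Cl)ncnc32)cc1` gives 0%
compound 3 `c1ccc(Cn2cnc3c(Sc4ccccc4)ncnc32)cc1` gives 1%

All three numbers sit together within the scatter, so none of the compounds can be set apart from the others. Compound 2 differs from compound 1 by fluoro in place of hydrogen on an aromatic carbon, and that change produced no change at the digits printed from compound 1 to compound 2 (within the scatter). Compound 3 carries a different core; the difference from compound 1 is phenylsulfanyl in place of chloro on an aromatic carbon, and the step was a number 1 percentage points higher from compound 1 to compound 3 (within the scatter).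

Compound 4 `Fc1ccc(Sc2ncnc3c2ncn3Cc2ccccc2)cc1` has not been measured. Its difference from compound 3 is fluoro in place of hydrogen on an aromatic carbon, which is the same change that turns compound 1 into compound 2, at the same kind of place. In this assay the expected step is no change at the digits printed from compound 3 to compound 4 (within the scatter), because the identical change gave no change at the digits printed from compound 1 to compound 2 (within the scatter). In this assay compound 4 is therefore expected to give 1%, with a plausible range from 0% to 8%.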

Compound 4, a percentage reported as inhibition, at one concentration (the size of the read-out at that concentration, not a potency): 1%
For compound 4 middle estimate and measured number coincide at the digits printed, and the stated range covers the measured number.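

In this assay, within the data shown here, fluoro in place of hydrogen gave no change at the digits printed from compound 3 to compound 4 (within the scatter), and the change reads alike on the two cores: the same change on two cores in this assay, no change at the digits printed (within the scatter) from compound 1 to compound 2 and no change at the digits printed (within the scatter) from compound 3 to compound 4, 0 percentage points apart, within the scatter of two such steps Replacing chloro with (4-fluorophenyl)sulfanyl gave a number 1 percentage points higher from compound 1 to compound 4 (within the scatter), so this larger exchange cannot be told apart from no step either. Among these compounds, the agreement shows only that the fluoro change produces no readable step on either core; with all the numbers this low, it does not show whether the change would carry over unaltered on a compound with clear inhibition at the concentration tested.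

On these data alone, it remains open whether any compound can give a number in this assay that stands clear of the scatter. Also open, as far as these compounds go, is what an amine in place of chloro, or a carboxylic acid on the phenyl ring of the phenylsulfanyl group, would do to the reading.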